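The source may hold more compounds than are shown below. What is called first, only, known or untested is meant among the compounds shown, and "the series" means these compounds.

Among the compounds with values here, compound 1 `N=C(N)NCCC[C@@H](NC(=O)c1cc2cc(F)ccc2[nH]1)C(=O)NCc1ccc(C(F)(F)F)cc1` gives 25 nM in a functional assay on HEK293 cells for antagonist activity at melanin-concentrating hormone receptor 1 (Homo sapiens) (a higher number here means a weaker inhibitor, a lower number a stronger inhibitor), the lowest of the two numbers recorded so far, and it stands well apart from its only neighbour. Compound 2 `N=C(N)NCCC[C@@H](NC(=O)c1ccnc2ccccc12)C(=O)NCc1ccc(C(F)(F)F)cc1` differs from it only in the group on the carbonyl carbon and gives 1030 nM in this assay; the step of a 41-fold higher number from compound 1 to compound 2 (1.61 log units; beyond the scatter) is a large loss of potency. Compound 3 `N=C(N)NCCC[C@@H](NC(=O)c1ccc2ccccc2c1)C(=O)NCc1ccc(C(F)(F)F)cc1` has not yet been measured. Its change from compound 1 is naphthalen-2-yl in place of 5-fluoro-1H-indol-2-yl on a carbonyl carbon. Like the change to compound 2, it removes the five-membered aromatic ring with its hydrogen-bond donor, but what enters here is two six-membered aromatic rings of carbon only, without the ring nitrogen of quinolin-4-yl, so the shape of the bicycle sits closer to that of compound 1 than quinolin-4-yl does. Within the data shown here, the single step that bears on this change is the large loss seen from compound 1 to compound 2. A loss is therefore expected for compound 3 too, though a smaller one, estimated as a 6.0-fold higher number from compound 1 to compound 3 (0.78 log units; beyond the scatter) in this assay. Compound 3 is expected to give 150 nM, with a range from 40 nM to 600 nM.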

Compound 3, half-maximal inhibitory concentration: 212 nM
The estimate for compound 3 lay 1.4-fold (0.15 log units) below the measured number, within the range that was stated.
By their numbers in this assay, from the lowest: compound 1; then compound 3; then compound 2.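

Swapping 5-fluoro-1H-indol-2-yl for naphthalen-2-yl, a two-ring aromatic group of equal heavy-atom count built of carbon only, still weakens compound 3 in this assay, with an 8.5-fold higher number from compound 1 to compound 3 (0.93 log units; beyond the scatter), so this place on the carbonyl carbon does not treat all two-ring aromatic groups alike. The loss is also not the same for every group without the ring hydrogen-bond donor, as naphthalen-2-yl recovers part of what quinolin-4-yl gave up, with a 4.9-fold lower number from compound 2 to compound 3 (0.69 log units; beyond the scatter). No measurement is available that explains this order of the three groups.

The change to compound 3 alters several things at once: it removes the fluorine and the ring nitrogen with its hydrogen, and it replaces the five-membered ring with a six-membered one, so the compounds shown cannot say which of these accounts for the loss. Likewise, quinolin-4-yl and naphthalen-2-yl differ both in the ring nitrogen and in the point of attachment, and 1H-indol-2-yl without the fluorine, benzofuran-2-yl with oxygen in the five-membered ring, or naphthalen-1-yl would each help to pull these effects apart.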